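The source may hold more compounds than are shown below. What is called first, only, known or untested is meant among the compounds shown, and "the series" means these compounds.

Measured compounds and values:
- compound 1, `C=C(C)[C@H]1CC=C(C)C2=CO[C@@H](c3ccccc3F)[C@@H]21`: 1000 nM
- compound 2, `C=C(C)[C@H]1CC=C(C)[C@@]2(O)[C@@H]1[C@H](c1ccccc1Br)O[C@@H]2C(=O)OCC1CC1`: 50000 nM
- compound 3, `C=C(C)[C@H]1CC=C(C)C2=CO[C@@H](c3cccc4ccccc34)[C@@H]21`: a limit, > 100000 nM

In a functional assay on KB3 cells (Homo sapiens) for antiproliferative activity, read by MTT assay, with a stated time of 96 h (a higher number here means a weaker inhibitor, a lower number a stronger inhibitor), compound 1 gives 1000 nM and so stands lowest of the two numbers shown. Compound 2 gives 50000 nM in this assay, a gap to compound 1 that lies beyond the scatter; compound 2 also carries a different core, so the two values show no single change. Compound 3 reaches only the limit of the assay, > 100000 nM, with the limit of > 100000 nM in this assay, at which 1 of the 3 values shown sits, marking where that limit sits.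

Compound 4, `C=C(C)[C@H]1CC=C(C)C2=CO[C@@H](c3ccccc3Br)[C@@H]21`, is not yet measured. It differs from compound 1 by bromo in place of fluoro on an aromatic carbon. Within the data shown here, no pair of measured compounds isolates this exchange. The step from compound 1 to compound 4 is expected to be small, a 1.5-fold higher number from compound 1 to compound 4 (0.18 log units; within the scatter), and may lie within the scatter in either direction. For compound 4 in this assay the estimate is 1500 nM, with a range from 400 nM to 8000 nM.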

Compound 4, half-maximal inhibitory concentration: 4000 nM
For compound 4 the middle estimate is 2.7-fold (0.43 log units) below the measured one, within the range that was stated.
By their numbers in this assay, from the lowest: compound 1; then compound 4; then compound 2. At a limit, above all of these: compound 3.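

Among these compounds, this pair gives the first single change that can be read. Among the compounds shown here, none of the earlier compounds differed in only one place. On an aromatic carbon, ortho to a large group, the identity of the halogen registers in this assay: bromo in place of fluoro gives a 4.0-fold higher number from compound 1 to compound 4 (0.60 log units; beyond the scatter) on the shared core, so this position is not indifferent to the change, though the step is modest. No measured property shown here bears on this step, and the data offer no account of it.

With only two halogens compared, the trend at this carbon rests on a single pair. Chloro or the unsubstituted ring would show whether the step extends to other substituents, while a methoxy group or an amine on the same carbon would test groups beyond the halogens.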